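This account rests on a few compounds, and the source may have more. Where it says the series, first, only, none or still open, it means among the compounds named here.

Compound 3 `CC(=O)N1CCC(NS(=O)(=O)c2ccc(NC(=O)c3ccccc3C)c3ccccc23)CC1` stands highest of the three numbers in an assay on L1.2 cells for binding affinity to C-C chemokine receptor type 8 (Homo sapiens); a higher number here means a weaker inhibitor, a lower number a stronger inhibitor: compound 3 gives 6.7 nM. Its nearest neighbour is compound 1 `O=C(Nc1ccc(S(=O)(=O)NC2CCCCC2)c2ccccc12)c1ccccc1`, which in this assay gives 4.4 nM, a gap that lies within the scatter. Furthest away is compound 2 `CCOC(=O)N1CCC(NS(=O)(=O)c2ccc(NC(=O)c3ccccc3)c3ccccc23)CC1`, which in this assay gives 0.17 nM. Compound 4 `Cc1ccccc1C(=O)Nc1ccc(S(=O)(=O)NC2CCN(C(N)=O)CC2)c2ccccc12` differs from compound 3 in one place: amino in place of methyl on a carbonyl carbon. Among the compounds with values here, the only measured step, a 26-fold lower number from compound 1 to compound 2 (1.41 log units; beyond the scatter), changes a different part of the shared core and so bears only loosely on this swap. Within the data shown here, no measured pair tests amino in place of methyl on that carbonyl carbon, so no step beyond the scatter is expected. Compound 4 is therefore expected at 5 nM, between 1.5 nM and 15 nM. That estimate amounts to an expected 1.3-fold lower number from compound 3 to compound 4 (0.13 log units; within the scatter).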

Compound 4, inhibition constant: 243 nM
Compound 4: the middle estimate sits 49-fold (1.69 log units) below what was measured; the whole stated range lies below it.
By their numbers in this assay, from the lowest: compound 2; then compounds 1 and 3 (each within the scatter of the next); then compound 4.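

In this assay, amino in place of methyl on a carbonyl carbon gives a 36-fold higher number from compound 3 to compound 4 (1.56 log units; beyond the scatter). Exchanging one heavy atom for another at this position, with one hydrogen-bond donor added and no net charge introduced, is therefore enough to produce a large step. No measurement shown here explains why the swap has so large an effect. The compounds shown leave open whether a methylamino or dimethylamino group on that carbonyl carbon would give a number closer to that of compound 3 or compound 4.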